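Benzyloxy in place of fluoroethoxy on a diethylacetamide aniline

The source may report more compounds than this note shows. Statements on the series, on what has been measured and on what is new or still open speak of the compounds shown alone.

Two members of this series have been measured so far in an assay on membranes from HEK293 cells for displacement of a labelled ligand from Translocator protein (Homo sapiens), read by scintillation counting, with a stated time of 90 min; on this read-out higher numbers stand for weaker inhibition and lower numbers for stronger inhibition. Compound 1 `CC(=O)N(Cc1ccc(OCc2ccccc2)cc1)c1cc(C)cc(C)c1` gives 377 nM in this assay. Compound 2 `CCN(CC)C(=O)CN(Cc1ccc(OCCF)cc1)c1cc(C)cc(C)c1` gives 1290 nM in this assay. Within the data shown here, compound 2 therefore has the higher of the two numbers, and its gap to compound 1, the only other compound measured, lies beyond the usual scatter.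

The step under consideration leads from compound 2 to compound 3 `CCN(CC)C(=O)CN(Cc1ccc(OCc2ccccc2)cc1)c1cc(C)cc(C)c1`, which has not yet been measured. The change is phenyl in place of fluoromethyl on a saturated chain carbon bound to an oxygen on an aromatic ring. Put another way, the 2-fluoroethoxy group of compound 2 is exchanged for the benzyloxy group that compound 1 carries, while the diethylacetamide side chain of compound 2 is kept.

Among the measured compounds shown here, no measured pair isolates this change, so the expectation rests on the fact that the benzyloxy-bearing compound 1 gives 377 nM in this assay, the lower of the two numbers. Compound 3 is accordingly expected to show a move to a lower number beyond the scatter, a step of a 6.5-fold lower number from compound 2 to compound 3 (0.81 log units; beyond the scatter). The estimate for compound 3 in this assay is 200 nM, with a range from 40 nM to 900 nM.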

Compound 3, inhibition constant: 433 nM
Estimate against measurement, compound 3: 2.2-fold (0.34 log units) below; the range from low to high includes it.
By their numbers in this assay, from the lowest: compounds 1 and 3 (each within the scatter of the next); then compound 2.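

Among these compounds, with the diethylacetamide side chain held constant, phenyl in place of fluoromethyl on a saturated chain carbon bound to an oxygen on an aromatic ring gives in this assay a 3.0-fold lower number from compound 2 to compound 3 (0.47 log units; beyond the scatter), a modest step that provides the first direct reading of this change. With the benzyloxy group held constant, (diethylcarbamoyl)methyl in place of acetyl on a nitrogen on an aromatic ring gives a 1.1-fold higher number from compound 1 to compound 3 (0.06 log units; within the scatter), so the two groups on that nitrogen are not told apart on this read-out, and the larger diethylamide-bearing group neither adds to nor takes from the number that the acetyl compound gives. Nothing available here explains either step.

The compounds shown leave open whether the lower number of compound 3 requires an aromatic ring on that chain carbon, or whether a cyclohexyl group, a pyridine ring or a longer unbranched alkyl chain would serve as well. They also leave open how a fluorine or a methoxy group on the benzyl ring, or an amine or a carboxylic acid in place of the diethylamide, would read in this assay.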